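Adding a Phenyl Ring to the Most Soluble Urea

The compounds below may be only part of what the source reports. "The series", "measured", "known", "first", "only" and "open" are said of these compounds alone.

Of the compounds shown here, three sharing the same core have been measured in a physicochemical assay for solubility, read by HPLC, measured as kinetic solubility, at pH 7; on this read-out higher numbers stand for higher solubility and lower numbers for lower solubility. Compound 2 `O=C(Nc1ccc(OC(F)(F)F)cc1)N[C@@H]1COc2nc([N+](=O)[O-])cn2C1` stands highest of the three, giving 93 ug/mL. Compound 1 `O=[N+]([O-])c1cn2c(n1)OC[C@@H](OCc1ccc(-c3ccc(OC(F)(F)F)cc3)cc1)C2` gives 1.2 ug/mL, and compound 3 `O=C(COc1ccc(-c2ccc(OC(F)(F)F)cc2)cc1)N[C@@H]1COc2nc([N+](=O)[O-])cn2C1` gives 0.96 ug/mL; both gaps from compound 2 lie well beyond the scatter of the measurement.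

Compound 4 `O=C(Nc1ccc(-c2ccc(OC(F)(F)F)cc2)cc1)N[C@@H]1COc2nc([N+](=O)[O-])cn2C1` has not yet been measured. It differs from compound 2 in one place: 4-(trifluoromethoxy)phenyl in place of trifluoromethoxy on an aromatic carbon. Compounds 1 and 3 already carry a 4-(trifluoromethoxy)phenyl group, and both give low numbers in this assay, though neither differs from compound 2 in only one place, so their gaps to compound 2 cannot be read as a clean single step.

Still, the three measured numbers point toward a large fall. The step from compound 2 to compound 4 is expected to be downward and beyond the scatter, a 31-fold lower number from compound 2 to compound 4 (1.49 log units; beyond the scatter). Compound 4 is therefore estimated at 3 ug/mL, with a likely range from 0.8 ug/mL to 12 ug/mL. That expectation rests on compound 1, which gives 1.2 ug/mL while carrying the same 4-(trifluoromethoxy)phenyl group.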

Compound 4, solubility: 0.17 ug/mL
Beside the measured number, compound 4's estimate is 18-fold (1.25 log units) above it; the measured number lies below the stated range.
By their numbers in this assay, from the lowest: compound 4; then compounds 3 and 1 (each within the scatter of the next); then compound 2.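

In this assay, for the compounds shown here, this is the first change in a single place, and putting 4-(trifluoromethoxy)phenyl in place of trifluoromethoxy gives a 550-fold lower number from compound 2 to compound 4 (2.74 log units; beyond the scatter). This position is therefore far from indifferent to what it carries: the number moves well beyond the scatter, although the hydrogen-bond donor and acceptor counts of the leaving and entering groups match and neither group carries a net charge. Nothing measured here accounts for the size of this step.

The compounds shown leave open whether an amine or a carboxylic acid on the added ring would raise the number while keeping that ring in place. They also leave open whether a pyridine ring in place of the added carbon ring would give a similar fall.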